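The source may hold more compounds than are shown below. What is called first, only, known or untested is meant among the compounds shown, and "the series" means these compounds.

Compound 3 `Cc1nc(S(C)(=O)=O)ccc1Oc1ncnc(OC2CCN(C(=S)OC(C)C)CC2)c1F` is the point of departure. In a functional assay on isolated protein for inhibition of Glucose-dependent insulinotropic receptor (Rattus norvegicus), read by HTRF and cAMP accumulation (a higher number here means that more compound is needed for the effect, a lower number that less compound is needed), compound 3 gives 1050 nM. Compound 1 `Cc1nc(S(C)(=O)=O)ccc1Oc1ncnc(OC2CCN(C(=O)O[C@H](C)CF)CC2)c1F` gives 1520 nM and compound 2 `Cc1nc(S(C)(=O)=O)ccc1Oc1ncnc(OC2CCN(C(=O)O[C@@H](C)CF)CC2)c1F` gives 1680 nM; the steps of a 1.4-fold lower number from compound 1 to compound 3 (0.16 log units; within the scatter) and a 1.6-fold lower number from compound 2 to compound 3 (0.20 log units; within the scatter) both stay within the scatter, so all three sit at about the same level, and a 1.1-fold higher number from compound 1 to compound 2 (0.04 log units; within the scatter) shows the same for the pair that differs only in configuration (the fact that compounds 1 and 2 differ only in the configuration as drawn). Compound 4 `Cc1nc(S(C)(=O)=O)ccc1Oc1ncnc(OC2CCN(C(=O)C3(F)CCC3)CC2)c1F` again alters the group on the ring nitrogen: a group of 7 heavy atoms (5 carbon, 1 oxygen, 1 fluorine; one four-membered non-aromatic ring of carbon only) in place of a group of 6 heavy atoms (4 carbon, 1 oxygen, 1 sulfur; no ring), on an amine nitrogen in a ring. The two measured changes at that same place were small, so a small step is expected here as well, in no clear direction. Expected, then, is a 1.0-fold higher number from compound 3 to compound 4 (0.02 log units; within the scatter). For compound 4 the estimate is 1100 nM, within a range from 450 nM to 2700 nM.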

Compound 4, half-maximal effective concentration: 123 nM
For compound 4 the middle estimate is 8.9-fold (0.95 log units) above the measured one, outside the stated range (below it).
By their numbers in this assay, from the lowest: compound 4; then compounds 3, 1 and 2 (each within the scatter of the next).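

At this position, the amine nitrogen of the six-membered ring, the number does respond to the group: in this assay the group with a four-membered carbon ring gives an 8.5-fold lower number from compound 3 to compound 4 (0.93 log units; beyond the scatter) and a 14-fold lower number from compound 2 to compound 4 (1.14 log units; beyond the scatter) and a 12-fold lower number from compound 1 to compound 4 (1.09 log units; beyond the scatter) as its steps. Among these compounds, the earlier changes at this place all stayed within the scatter, so this is the first change here that clearly lowers the number. Nothing measured here gives a reason for this drop. The compounds shown do not separate the contributions of the ring, the fluorine and the carbonyl. Going by these compounds, it remains open how a five-membered carbon ring, or hydrogen in place of the fluorine, would read in this assay.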